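A few compounds are considered here, and "the series" means these few. Any claim that something is new, unique, unknown or untested is made for them only; others in the source may bear on it.

Compound 1 has the structure `Nc1cc(N)c2nc(-c3ccccc3)c(Oc3ccc(Cl)c(Cl)c3)nc2c1`. In a functional assay on UO-31 cells (Homo sapiens) for inhibition, read by sulforhodamine B assay, with a stated time of 48 h (on this read-out lower numbers stand for stronger inhibition of growth and higher numbers for weaker inhibition of growth), compound 1 gives only a limit of the assay, < 100000 nM, so no exact number is known for it (the limit of < 100000 nM in this assay, at which 1 of the 2 values shown sits). A second compound, compound 2 with the structure `COc1cc(CNc2nc3cc(N)cc(N)c3nc2-c2ccccc2)cc(OC)c1OC`, was tested in the same way. In this assay compound 2 also gives only a limit, < 50200 nM (the limit of < 50200 nM in this assay, at which 1 of the 2 values shown sits). For the measured compounds named here, both measured values are therefore limits, and no step between them can be read. Compound 3 has the structure `Nc1cc(N)c2nc(-c3ccccc3)c(NCc3ccc(F)cc3)nc2c1` and differs from compound 1 in one place: (4-fluorobenzyl)amino in place of 3,4-dichlorophenoxy on an aromatic carbon. Going by the values given here, no measured step of this kind exists, so the expected step is a step that the limit leaves unreadable from compound 1 to compound 3, with no clear direction beyond the scatter. Compound 3 is thus estimated at 40000 nM in this assay, and the expected range runs from 8000 nM to 100000 nM.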

Compound 3, concentration for total growth inhibition: < 100000 nM
Compound 3 gave a limit, no number; the forecaster's own chance of this, stated with the estimate: 50%; the middle value is on the limit's open side.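

For the compounds shown here, compound 1 and compound 3 each give only a limit in this assay, so no step between them can be read. The compounds shown leave open how strongly each one inhibits growth, and whether (4-fluorobenzyl)amino in place of 3,4-dichlorophenoxy changes that at all.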